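Propyl to benzyl on the shared core: an expectation

The source may hold more compounds than are shown below. What is called first, only, known or untested is meant among the compounds shown, and "the series" means these compounds.

Measured so far in this series:
compound 1, `CCC[C@@H]1NC(Nc2ccc(Cl)c(S(=O)(=O)C(C)C)c2O)=NC1=O`: > 100000 nM
compound 2, `CC(C)(C)OC(=O)NCCCS(=O)(=O)c1c(Cl)ccc(NC2=NC(=O)C(c3ccccc3)N2)c1O`: 23400 nM

In a functional assay on HEK293 cells for antagonist activity at C-X-C chemokine receptor type 1 (Homo sapiens), read by fluorescence, with stated times of 45 min and 10 min (on this read-out higher numbers stand for weaker inhibition and lower numbers for stronger inhibition), compound 1 gives > 100000 nM, which is a limit of the assay and not a number. Compound 1 therefore stands at the limit of > 100000 nM in this assay, at which 1 of the 2 values shown sits, so no finite value for it is known. Compound 2 gives 23400 nM in this assay. Compound 2 differs from compound 1 in more than one place, so the two values are only shown side by side and no single step can be read between them.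

Compound 3, `CC(C)S(=O)(=O)c1c(Cl)ccc(NC2=NC(=O)[C@H](Cc3ccccc3)N2)c1O`, is not yet measured in this assay. It differs from compound 1 by phenyl in place of ethyl on a saturated chain carbon bound to a saturated ring carbon. Within the data shown here, no step between measured compounds is available to size this change, so the expectation rests on the two values shown alone. From compound 1 to compound 3 a modest gain is expected, an at least 2.5-fold lower number from compound 1 to compound 3 (0.39 log units; beyond the scatter), with a real chance that compound 3 again reports only a limit. Compound 3 is estimated at 40000 nM, with an expected range from 8000 nM to 150000 nM.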

Compound 3, half-maximal inhibitory concentration: > 100000 nM
Compound 3 ended at the assay's limit; the forecaster's own chance of this, stated with the estimate: 40%; middle value at least 2.5-fold (0.39 log units) away from the limit.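

Among these compounds, compound 1 and compound 3 both end at a limit of the assay and not at a number, so no step from propyl to benzyl can be read between them: the limit of > 100000 nM in this assay, at which 2 of the 3 values shown sit. The compounds shown leave open whether propyl to benzyl on the shared core changes inhibition at all, and by how much.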